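Methoxy for bromo on a sulfonyl analogue of an enone series

This account rests on a few compounds, and the source may have more. Where it says the series, first, only, none or still open, it means among the compounds named here.

Compound 1, `O=C(/C(=C\c1ccc(Br)cc1)SCc1ccc(Cl)cc1)c1ccc(Br)cc1`: 1000 nM
Compound 2, `COc1ccc(/C=C(/SCc2ccc(Cl)cc2)C(=O)c2ccc(Br)cc2)cc1`: 10000 nM
Compound 3, `O=C(/C(=C\c1ccc(Br)cc1)S(=O)(=O)c1ccc(Br)cc1)c1ccc(Br)cc1`: 10000 nM

Of the compounds shown here, three have been measured in a functional assay on DU-145 cells (Homo sapiens) for inhibition, read by trypan blue exclusion, with a stated time of 96 h; a higher number here means a weaker inhibitor of growth, a lower number a stronger inhibitor of growth. Compound 1 gives 1000 nM in this assay. Compound 2 carries a single change relative to compound 1, (methoxy in place of bromo on an aromatic carbon), and the step of a 10-fold higher number from compound 1 to compound 2 (1.00 log units; beyond the scatter). Compound 3, which in this assay gives 10000 nM, differs from compound 1 in its core; the difference between the two cores is not broken down here. Compound 3 stands level with compound 2, within the scatter, and its number is higher than that of compound 1 beyond the scatter.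

Compound 4, `COc1ccc(S(=O)(=O)/C(=C/c2ccc(Br)cc2)C(=O)c2ccc(Br)cc2)cc1`, has not been measured. It differs from compound 3 by methoxy in place of bromo on an aromatic carbon, the same change that separates compound 1 from compound 2. Because the step of a 10-fold higher number from compound 1 to compound 2 (1.00 log units; beyond the scatter) weakened growth inhibition, the same change from compound 3 to compound 4 is expected to give a 2.0-fold higher number from compound 3 to compound 4 (0.30 log units; within the scatter) in this assay. Compound 4 is therefore estimated at 20000 nM, within 7000 nM to 100000 nM, with a fair chance that the assay reports only a limit.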

Compound 4, concentration for 50% growth inhibition: 6000 nM
Compound 4: the middle estimate sits 3.3-fold (0.52 log units) above what was measured, outside the stated range (below it).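

In this assay, within the data shown here, methoxy in place of bromo gives a 1.7-fold lower number from compound 3 to compound 4 (0.22 log units; within the scatter), so on the core of compound 3 this change produces no step that can be told from the scatter. On the core of compound 1 the same change clearly raised the number, so its effect did not carry over from one core to the other: the same change on two cores in this assay, a 10-fold higher number (1.00 log units; beyond the scatter) from compound 1 to compound 2 and a 1.7-fold lower number (0.22 log units; within the scatter) from compound 3 to compound 4, 17-fold (1.22 log units) apart, beyond the scatter of two such steps

This rests on a single pair of steps and does not show which of the differences between the two cores accounts for the gap, nor how the change would behave on any further core.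

The compounds shown leave open whether an amine or a carboxylic acid in place of bromo would follow the step seen on one core, the other, or neither. They also leave open whether a smaller alteration to the core of compound 1, short of the full difference from the core of compound 3, would be enough to make the two steps diverge.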